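The compounds below may be only part of what the source reports. "The series", "measured", "known", "first", "only" and "open" are said of these compounds alone.

Compound 1, `CCCCCCCCCCCCCCc1ccc(NC(=O)Nc2c(C(C)C)cccc2C(C)C)cc1`: in an assay on isolated protein for inhibition of acyl-CoA:cholesterol acyltransferase (Oryctolagus cuniculus) (on this read-out lower numbers stand for stronger inhibition and higher numbers for weaker inhibition), compound 1 gives 500 nM.
Compound 2, `CCc1ccc(NC(=O)Nc2c(C(C)C)cccc2C(C)C)cc1`: in this assay compound 2 gives 100 nM.

Going by the values given here, compound 2 holds the lower of the two numbers, the only comparison being a 5.0-fold lower number from compound 1 to compound 2 (0.70 log units; beyond the scatter), a modest gain when the long chain was cut back. Compound 3, `CCCCCCCc1ccc(NC(=O)Nc2c(C(C)C)cccc2C(C)C)cc1`, differs from compound 2 by pentyl in place of hydrogen on a saturated chain carbon, two bonds along the chain from an aromatic carbon, so its chain sits between those of the two measured compounds. Since lengthening the chain cost potency once, a moderate rise in the number is expected, smaller than the measured step. Compound 3 is therefore expected to give 200 nM, within 80 nM to 600 nM, meaning an expected 2.0-fold higher number from compound 2 to compound 3 (0.30 log units; within the scatter).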

Compound 3, half-maximal inhibitory concentration: 19 nM
Compound 3: the middle estimate sits 11-fold (1.02 log units) above what was measured; measured number below the stated range.
By their numbers in this assay, from the lowest: compound 3; then compound 2; then compound 1.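

Lengthening the chain at this position does not simply cost potency: going from ethyl to heptyl gives a 5.3-fold lower number from compound 2 to compound 3 (0.72 log units; beyond the scatter) in this assay while heptyl set against the much longer chain gives a 26-fold lower number from compound 1 to compound 3 (1.42 log units; beyond the scatter) for the same read-out. Among these three compounds, the middle length holds the lowest number, with both the shorter and the longer chain giving higher ones. Nothing measured here explains this rise and fall with chain length.

Where the lowest number falls remains open, since butyl and octyl could match or beat heptyl. Also open, on these data alone, is how a chain carrying an amine would compare.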